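A few compounds are considered here, and "the series" means these few. Any claim that something is new, unique, unknown or untested is made for them only; others in the source may bear on it.

Compound 1 `COc1cc(Cl)cc(-c2nn(-c3cccc(NC(=O)Nc4cccc(C(F)(F)F)c4)c3)cc2-c2ccncc2)c1` gives 98% in a functional assay on SNB-19 cells (Homo sapiens) for inhibition, read by sulforhodamine B assay, with a stated time of 48 h, tested at 0.01 uM; on this read-out higher numbers stand for a weaker effect at the one concentration tested and lower numbers for a stronger effect. Compound 2 `COc1cc(Cl)cc(-c2nn(-c3cccc(NC(=O)Nc4ccc(Cl)c(C(F)(F)F)c4)c3)cc2-c2ccncc2)c1` gives 92%, and compound 3 `COc1cc(Cl)cc(-c2nn(-c3cccc(NC(=O)c4cccc(C(F)(F)F)c4)c3)cc2-c2ccncc2)c1` gives 96% in this assay. The number for compound 2 is the smallest of the three, yet a number 6 percentage points lower from compound 1 to compound 2 (within the scatter) and a number 4 percentage points higher from compound 2 to compound 3 (within the scatter) both lie within the scatter, as does a number 2 percentage points lower from compound 1 to compound 3 (within the scatter). Compound 4 `O=C(Nc1cccc(-n2cc(-c3ccncc3)c(-c3cc(O)cc(Cl)c3)n2)c1)Nc1ccc(Cl)c(C(F)(F)F)c1` differs from compound 2 by hydrogen in place of methyl on an oxygen on an aromatic ring. Neither measured step touches the methoxy: the steps concern the urea and amide end of the molecule, and every one of them stayed within the scatter. No basis exists for expecting more than scatter here, so the estimated step is a number 2 percentage points higher from compound 2 to compound 4 (within the scatter). In this assay compound 4 is therefore expected to give about 94%, between 84% and 100%.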

Compound 4, a percentage reported as activity, at one concentration (the size of the read-out at that concentration, not a potency): 95%
Compound 4: middle estimate off by 1 percentage points, on the low side, within the range that was stated.
By their numbers in this assay, from the lowest: compounds 2, 4, 3 and 1 (each within the scatter of the next).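

Methoxy to hydroxy on the 3-chloro-5-methoxyphenyl group gives a number 3 percentage points higher from compound 2 to compound 4 (within the scatter) in this assay, the first reading at this position, since the earlier steps all concerned the urea and amide end. At the one concentration tested, hydrogen can thus stand in place of methyl on this oxygen without the number leaving the scatter. Nothing at hand bears on this result.

Open, as far as these compounds go, is whether an amine or an ethoxy group at this place on the aromatic ring would read differently. Also open, from the compounds shown here alone, is whether compound 2 and compound 4 would separate at a higher concentration.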